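The source may hold more compounds than are shown below. What is called first, only, known or untested is meant among the compounds shown, and "the series" means these compounds.

Measured in a functional assay on COLO 205 cells (Homo sapiens) for inhibition, read by sulforhodamine B assay; a higher number here means a weaker inhibitor of growth, a lower number a stronger inhibitor of growth:
compound 1, `FC(F)(F)Oc1ccc(-c2ccc(-c3ccc(-c4nc5ccccc5[nH]4)cc3)cc2)cc1`, gives 100000 nM;
compound 2, `Oc1ccc(-c2ccc(-c3ccc(-c4nc5ccccc5[nH]4)cc3)cc2)cc1`, gives 100000 nM;
compound 3, `Cc1ccc2[nH]c(-c3ccc(-c4ccc(-c5ccc(OC(F)(F)F)cc5)cc4)cc3)nc2c1`, gives 30600 nM.

Compound 4, `Cc1ccc2[nH]c(-c3ccc(-c4ccc(-c5ccc(O)cc5)cc4)cc3)nc2c1`, has not yet been measured in this assay.

Compound 2 differs from compound 1 by hydrogen in place of trifluoromethyl on an oxygen on an aromatic ring. That change made the step of no change at the digits printed from compound 1 to compound 2 (within the scatter). Compound 3 differs from compound 1 in its core, by methyl in place of hydrogen on an aromatic carbon, and that change made the step of a 3.3-fold lower number from compound 1 to compound 3 (0.51 log units; beyond the scatter), which leaves compound 3 with the lowest of the three measured numbers. Going by the values given here, compound 4 differs from compound 3 by hydrogen in place of trifluoromethyl on an oxygen on an aromatic ring, the same change at the same place as the one between compound 1 and compound 2. On the core of compound 3, the step from compound 3 to compound 4 in this assay is expected to be a 1.3-fold higher number from compound 3 to compound 4 (0.12 log units; within the scatter), an expectation resting on the flat result of no change at the digits printed from compound 1 to compound 2 (within the scatter); with a single earlier example it is held loosely. Compound 4 is accordingly estimated at 40000 nM, between 15000 nM and 100000 nM.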

Compound 4, concentration for 50% growth inhibition: 100000 nM
Estimate against measurement, compound 4: 2.5-fold (0.40 log units) below, within the range that was stated.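

In this assay, the change from trifluoromethoxy to hydroxy gave a 3.3-fold higher number from compound 3 to compound 4 (0.51 log units; beyond the scatter), so it did not carry over as a fixed step from the core of compound 1 to the core of compound 3: the same change on two cores in this assay, no change at the digits printed (within the scatter) from compound 1 to compound 2 and a 3.3-fold higher number (0.51 log units; beyond the scatter) from compound 3 to compound 4, 3.3-fold (0.51 log units) apart, beyond the scatter of two such steps
Read the other way, methyl in place of hydrogen on an aromatic carbon gave no change at the digits printed from compound 2 to compound 4 (within the scatter), so that change also differed between the trifluoromethoxy and hydroxy compounds: the same change on two cores in this assay, a 3.3-fold lower number (0.51 log units; beyond the scatter) from compound 1 to compound 3 and no change at the digits printed (within the scatter) from compound 2 to compound 4, 3.3-fold (0.51 log units) apart, beyond the scatter of two such steps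
Going by these compounds alone, neither change transfers as a fixed amount across these four compounds, but this rests on a single set of two cores, with compound 3 the only one whose printed number differs from the others, and it does not show why the steps differ or how another core would behave.

As far as these compounds go, it remains open whether an amine or a carboxylic acid in place of the hydroxy would lower the number on either core. From the compounds shown here alone, it also remains open whether a longer chain in place of the methyl would do so.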